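From cyano to acetamido: a group not yet tested

The source may hold more compounds than are shown below. What is called first, only, known or untested is meant among the compounds shown, and "the series" means these compounds.

Three compounds share one core and differ in a single group on an aromatic ring. In a functional assay on HepG2 cells (Homo sapiens) for cytotoxicity, read by MTT assay, with a stated time of 24 h (a higher number here means a weaker inhibitor, a lower number a stronger inhibitor), compound 1 `O=C1/C(=C/c2ccncc2)CN(S(=O)(=O)c2ccc(C(F)(F)F)cc2)C/C1=C\c1ccccc1C(F)(F)F` gives 3240 nM and compound 2 `O=C1/C(=C/c2ccncc2)CN(S(=O)(=O)c2ccc(F)cc2)C/C1=C\c1ccccc1C(F)(F)F` gives 4010 nM while compound 3 `N#Cc1ccc(S(=O)(=O)N2C/C(=C\c3ccncc3)C(=O)/C(=C/c3ccccc3C(F)(F)F)C2)cc1` gives 5920 nM on the same scale. Compound 3 stands level with the other two: the gaps are a 1.5-fold higher number from compound 2 to compound 3 (0.17 log units; within the scatter) and a 1.8-fold higher number from compound 1 to compound 3 (0.26 log units; within the scatter) and neither counts as a real difference.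

As far as these compounds go, the next change from compound 3 is acetamido in place of cyano on an aromatic carbon and it gives compound 4 `CC(=O)Nc1ccc(S(=O)(=O)N2C/C(=C\c3ccncc3)C(=O)/C(=C/c3ccccc3C(F)(F)F)C2)cc1` whose number is still unknown. The remaining swap among the measured compounds is a 1.2-fold higher number from compound 1 to compound 2 (0.09 log units; within the scatter) and so all three swaps of this kind have stayed small. For the measured compounds named here, no measured compound carries acetamido, which leaves this guide a loose one. No step beyond the scatter is expected, and the estimated move in this assay is a 1.3-fold lower number from compound 3 to compound 4 (0.13 log units; within the scatter) and nothing larger. The estimate for compound 4 is 4400 nM with an expected range from 2000 nM to 10000 nM as its likely span.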

Compound 4, half-maximal inhibitory concentration: 4840 nM
The estimate for compound 4 lay 1.1-fold (0.04 log units) below the measured number; the range from low to high includes it.
By their numbers in this assay, from the lowest: compounds 1, 2, 4 and 3 (each within the scatter of the next).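

Acetamido is the larger group by heavy-atom count and, unlike cyano, brings a hydrogen-bond donor, yet in this assay the steps stay small: a 1.2-fold lower number from compound 3 to compound 4 (0.09 log units; within the scatter) and a 1.2-fold higher number from compound 2 to compound 4 (0.08 log units; within the scatter) and a 1.5-fold higher number from compound 1 to compound 4 (0.17 log units; within the scatter). So at this aromatic carbon, para to a large group, trifluoromethyl, fluoro, cyano and acetamido cannot be told apart in this assay, and adding a donor to the range of groups has not separated the compounds. Nothing available here explains why the numbers stay so close.

As far as these compounds go, whether an amine, a carboxylic acid or a longer chain at this place would move the number beyond the scatter stays open. Also open, from the compounds shown here alone, is whether this position would stay as insensitive if other parts of the shared core were changed.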